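A few compounds are considered here, and "the series" means these few. Any claim that something is new, unique, unknown or untested is made for them only; others in the source may bear on it.

In a functional assay on SGC-7901 cells (Homo sapiens) for cytotoxicity, read by sulforhodamine B assay, with a stated time of 72 h (a higher number here means a weaker inhibitor, a lower number a stronger inhibitor), two of the three measured compounds give numbers. Compound 1 `C=C1C(=O)O[C@@H]2CC(C)=C([C@@H](C)CCCOC(C)=O)[C@@H](OC(=O)CN3CCCC3)[C@H]12` gives 18400 nM. Compound 2 `C=C1C(=O)O[C@@H]2CC(C)=C([C@@H](C)CCCOC(C)=O)[C@@H](OC(=O)COc3cccc4[nH]nnc34)[C@H]12` gives 21100 nM. Among the measured compounds shown here, the single measured step, a 1.1-fold higher number from compound 1 to compound 2 (0.06 log units; within the scatter), therefore shows no shift beyond the scatter. Compound 3 `CC(=O)OCCC[C@H](C)C1=C(C)C[C@H]2OC(=O)C(CSCCO)[C@H]2[C@@H]1OC(C)=O` stands apart from those two. For compound 3 the result in this assay is > 100000 nM, which is a limit of the assay and not a number, as described by the limit of > 100000 nM in this assay, at which 1 of the 3 values shown sits. The step to be followed leads to compound 4 `CC(=O)OCCC[C@H](C)C1=C(C)C[C@H]2OC(=O)C(CSCCO)[C@H]2[C@@H]1OC(=O)c1ccccc1`, and the change is phenyl in place of methyl on a carbonyl carbon. For the measured compounds named here, no measured step covers this change: the step from compound 1 to compound 2 alters a different group, on a saturated chain carbon bound to a carbonyl carbon, and concerns a different pair of compounds, so it gives no guide to direction or size here. Starting from a limit, the estimate for compound 4 is 100000 nM, expected between 30000 nM and 300000 nM. The expected step, a number no higher from compound 3 to compound 4 (the limit leaves the size open), is thus taken to be none beyond the scatter, with a real chance that only a limit is reported again.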

Compound 4, half-maximal inhibitory concentration: > 100000 nM
Compound 4 ended at the assay's limit (the forecaster's own chance of this, stated with the estimate: 60%); the middle value lies on the limit itself.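

No step can be read from compound 3 to compound 4, as each result is a limit of the assay and not a number: the limit of > 100000 nM in this assay, at which 2 of the 4 values shown sit.

The compounds shown leave open whether phenyl in place of methyl on a carbonyl carbon changes the result in this assay at all, and in which direction.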